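The source may report more compounds than this note shows. Statements on the series, on what has been measured and on what is new or still open speak of the compounds shown alone.

Of the compounds shown here, three built on one shared core have been tested in a functional assay on HepG2 cells (Homo sapiens) for antiproliferative activity, read by MTT assay, with a stated time of 24 h (a lower number here means a stronger inhibitor, a higher number a weaker inhibitor), and a fourth is still to be measured. Compound 1 `COc1ccc(C(=O)/C=C/c2cc(OC)c(OC)c(OC)c2)c2c1C=CC(C)(C)O2` carries a trimethoxyphenyl group at one end. Compound 2 `COc1ccc(C(=O)/C=C/c2ccc(F)cc2)c2c1C=CC(C)(C)O2` carries a 4-fluorophenyl group in that place. Compound 3 `COc1ccc(C(=O)/C=C/c2ccc3ccccc3c2)c2c1C=CC(C)(C)O2` carries a naphthyl group there. Compound 1 reached only the limit of the assay, giving > 10000 nM. Compound 2 likewise reached only the limit, giving > 10000 nM. Compound 3 gave a real number, 210 nM. Compound 2 therefore stands at the limit of > 10000 nM in this assay, at which 2 of the 3 values shown sit, and where it truly lies beyond that is not known. Compound 4 `COc1ccc(C(=O)/C=C/c2ccc([N+](=O)[O-])cc2)c2c1C=CC(C)(C)O2` differs from compound 2 by nitro in place of fluoro on an aromatic carbon. Going by the values given here, no two measured compounds differ in only one place, so no measured step guides this change. The expected step from compound 2 to compound 4 is a step that the limit leaves unreadable from compound 2 to compound 4, which is taken to be none beyond the scatter. Compound 4 is thus expected to give about 12000 nM in this assay, within a range from 3000 nM to 40000 nM, most likely again as a limit.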

Compound 4, half-maximal inhibitory concentration: 2610 nM
For compound 4 the middle estimate is 4.6-fold (0.66 log units) above the measured one; the whole stated range lies above it.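

In this assay, going by these compounds alone, replacing fluoro with nitro gives an at least 3.8-fold lower number from compound 2 to compound 4 (0.58 log units; beyond the scatter), the first step in this set that can be read between two compounds differing in only one place. It shows that this single change, on an aromatic carbon para to a large group, is enough to turn a limit into a real number while the rest of the molecule stays the same. The true size of the step remains unknown because compound 2 has only a limit and not a number: the limit of > 10000 nM in this assay, at which 2 of the 4 values shown sit.

This one pair cannot say which feature of nitro matters, or whether the same change would have a similar effect on a different core. It also leaves open how an amine, a nitrile or a carboxylic acid in the same place would compare with nitro.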